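The source may hold more compounds than are shown below. What is called first, only, known or untested is meant among the compounds shown, and "the series" means these compounds.

Two compounds of the series carry numbers in a functional assay on DLD-1 cells (Homo sapiens) for antiproliferative activity, read by CellTiter-Glo, with a stated time of 72 h; on this read-out higher numbers stand for weaker inhibition and lower numbers for stronger inhibition. Compound 1 `Cc1cc(C)c(S(=O)(=O)N2CCC(N3CCC(CCO)CC3)CC2)c(C)c1` gives 19 nM, and compound 2 `Cc1cc(C)c(S(=O)(=O)N2CCC(N3CC(C)CC(C)C3)CC2)c(C)c1` gives 17 nM; these two stand side by side, since a 1.1-fold lower number from compound 1 to compound 2 (0.05 log units; within the scatter). Compound 3 `Cc1cc(C)c(S(=O)(=O)N2CCC(C3OCC(C)CO3)CC2)c(C)c1` differs from compound 2 by a group of 7 heavy atoms (5 carbon, 2 oxygen; one six-membered non-aromatic ring with 2 hetero atoms) in place of a group of 8 heavy atoms (7 carbon, 1 nitrogen; one six-membered non-aromatic ring with 1 hetero atom), on a saturated ring carbon. For the measured compounds named here, only one measured step touches the same place, namely a 1.1-fold lower number from compound 1 to compound 2 (0.05 log units; within the scatter), and it left the number where it was. Going by the values given here, the expected step in this assay is therefore a 2.1-fold higher number from compound 2 to compound 3 (0.31 log units; beyond the scatter), with the range widened because the change has no direct precedent. Compound 3 is estimated at 35 nM, between 10 nM and 150 nM.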

Compound 3, half-maximal inhibitory concentration: > 5000 nM
Compound 3 was reported as a limit (the forecaster's own chance of this, stated with the estimate: 3%); middle value at least 140-fold (2.15 log units) from the limit.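

Compound 3 stands only as a limit in this assay: the limit of > 5000 nM in this assay, at which 1 of the 3 values shown sits.

The two piperidine groups had left the number in place, but this position does not accept every six-membered ring: the ring with two oxygens in place of 3,5-dimethylpiperidin-1-yl gives an at least 290-fold higher number from compound 2 to compound 3 (2.46 log units; beyond the scatter). Against 4-(2-hydroxyethyl)piperidin-1-yl, the same ring gives an at least 260-fold higher number from compound 1 to compound 3 (2.42 log units; beyond the scatter).

The change removes the nitrogen and adds two oxygens in one step, so the compounds shown cannot separate the two. A cyclohexyl or a morpholin-4-yl group would address that question.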